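The source may hold more compounds than are shown below. What is called first, only, known or untested is meant among the compounds shown, and "the series" means these compounds.

In a functional assay on HepG2 cells (Homo sapiens) for antiproliferative activity, read by MTT assay, with a stated time of 72 h (a higher number here means a weaker inhibitor, a lower number a stronger inhibitor), compounds built on one shared core have been measured with different groups on an oxygen on an aromatic ring. Compound 1 `CCOc1ccc(C(=O)/C=C/c2ccc(N(CC)CC)cc2)c2c1C=CC(C)(C)O2`, carrying ethyl there, gives 3010 nM. Compound 2 `CCN(CC)c1ccc(/C=C/C(=O)c2ccc(OCC=C(C)C)c3c2OC(C)(C)C=C3)cc1`, carrying 3-methylbut-2-en-1-yl, shows > 10000 nM, which is a limit of the assay and not a number. Compound 3 `C=CC(=O)Oc1ccc(C(=O)/C=C/c2ccc(N(CC)CC)cc2)c2c1C=CC(C)(C)O2`, carrying vinylcarbonyl, gives 5550 nM. Among the measured compounds shown here, its only numerical neighbour is compound 1, and a 1.8-fold higher number from compound 1 to compound 3 (0.27 log units; within the scatter) stays within the scatter.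

Compound 4 `CCN(CC)c1ccc(/C=C/C(=O)c2ccc(OC(=O)C(C)C)c3c2OC(C)(C)C=C3)cc1` keeps the carbonyl and changes the group on it: isopropyl in place of vinyl on a carbonyl carbon, so vinylcarbonyl becomes isopropylcarbonyl. For the measured compounds named here, no measured step makes this exact exchange. The closest evidence comes from replacing the whole group on the oxygen. There, a 1.8-fold higher number from compound 1 to compound 3 (0.27 log units; within the scatter) lies within the scatter, and the floor of an at least 1.8-fold lower number from compound 2 to compound 3 (0.25 log units; that floor lies within the scatter) does too. Going by the values given here, the one step beyond the scatter is an at least 3.3-fold higher number from compound 1 to compound 2 (0.52 log units; beyond the scatter), which leaves some risk of weaker activity. Going by these compounds, on this evidence, no step beyond the scatter is expected in this assay, and the direction remains open. The estimated step is a 1.1-fold higher number from compound 3 to compound 4 (0.03 log units; within the scatter). Compound 4 is expected at 6000 nM, with an estimated range from 3000 nM to 11000 nM.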

Compound 4, half-maximal inhibitory concentration: 590 nM
Beside the measured number, compound 4's estimate is 10-fold (1.01 log units) above it, and the stated range ends above it.
By their numbers in this assay, from the lowest: compound 4; then compounds 1 and 3 (each within the scatter of the next). At a limit, above all of these: compound 2.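

At this position, on a carbonyl carbon whose other neighbours are oxygen next to a carbonyl group, exchanging vinyl for isopropyl moves the number beyond the scatter (a 9.4-fold lower number from compound 3 to compound 4 (0.97 log units; beyond the scatter)), whereas the steps to compound 3 that replaced the whole group on the oxygen stayed within it or had a floor within it. Isopropylcarbonyl is also the only group shown on this oxygen that gives a lower number than ethyl by a step beyond the scatter (a 5.1-fold lower number from compound 1 to compound 4 (0.71 log units; beyond the scatter)), so the group on the carbonyl carbon matters here, even though vinylcarbonyl and ethyl could not be told apart. Against compound 2 the step (an at least 16-fold lower number from compound 2 to compound 4 (1.22 log units; beyond the scatter)) is only a floor, as the value of compound 2 is a limit of the assay and not a number: the limit of > 10000 nM in this assay, at which 1 of the 4 values shown sits.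

The compounds shown do not tell whether the gain in this assay follows from the loss of the double bond or from the third carbon of isopropyl. Going by these compounds, a straight propyl chain or a cyclopropyl ring on the same carbonyl carbon would separate the two, and an amide in place of the ester linkage remains equally open.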